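Compound 3 to compound 4: carboxymethyl for trifluoromethyl

The compounds below may be only part of what the source reports. "The series", "measured", "known", "first", "only" and "open" are said of these compounds alone.

Values in a functional assay (mast cells) for inhibition, with Rattus norvegicus as the target; a higher number here means that more compound is needed for the effect, a lower number that less compound is needed:
- compound 1 `CCOC(=O)c1cnc2n(c1=O)C(C)CC/C2=N\Nc1ccccc1C(=O)O` gives 100000 nM
- compound 2 `CC1CCn2c(ncc(C(=O)O)c2=O)/C1=N/Nc1ccccc1` gives 5400 nM
- compound 3 `CC1CC/C(=N\Nc2ccc(C(F)(F)F)cc2)c2ncc(C(=O)O)c(=O)n21` gives 280 nM

Compound 3 has the lowest of the three numbers, and its gaps to compound 2 and compound 1 both lie beyond the scatter. Compound 4 `CC1CC/C(=N\Nc2ccc(CC(=O)O)cc2)c2ncc(C(=O)O)c(=O)n21` has carboxymethyl in place of trifluoromethyl on an aromatic carbon, para to a large group (carboxymethyl in place of trifluoromethyl on an aromatic carbon).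

Among the measured compounds shown here, no measured step isolates this exchange, so the expectation rests on loose comparisons. Compound 2, with no group on that ring, gives 5400 nM in this comparison. For the measured compounds named here, compound 1, the only measured compound with a carboxyl on that ring, gives 100000 nM but also differs elsewhere, so it offers only weak guidance. A rise in the number beyond the scatter is expected, with an estimated 18-fold higher number from compound 3 to compound 4 (1.25 log units; beyond the scatter) in this assay as the size of the step. For compound 4 the estimated value is 5000 nM within an expected range of 900 nM to 30000 nM for repeat measurements.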

Compound 4, half-maximal effective concentration: 3400 nM
Beside the measured number, compound 4's estimate is 1.5-fold (0.17 log units) above it, and the stated range covers the measured number.
By their numbers in this assay, from the lowest: compound 3; then compounds 4 and 2 (each within the scatter of the next); then compound 1.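

In this assay, carboxymethyl in place of trifluoromethyl on an aromatic carbon, para to a large group, gives a 12-fold higher number from compound 3 to compound 4 (1.08 log units; beyond the scatter), the first step measured between two groups at this position. The number therefore depends on which group stands there: compound 4 at 3400 nM and compound 2, with no group on that ring, at 5400 nM lie within the scatter of each other, so among these three only the trifluoromethyl of compound 3 goes with the lower number. No measurement at hand accounts for the step.

The compounds shown leave open how a methyl, a chlorine or a methoxy group at this place would read, and so whether trifluoromethyl stands apart from other groups. Also open, going by these compounds, is whether the methyl ester of the carboxymethyl group would stay level with compound 4 or move towards compound 3.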